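This account rests on a few compounds, and the source may have more. Where it says the series, first, only, none or still open, it means among the compounds named here.

Measured compounds in a functional assay on LM7 cells (Homo sapiens) for antiproliferative activity, read by MTT assay, with a stated time of 72 h; a lower number here means a stronger inhibitor, a higher number a weaker inhibitor:
compound 1 `COc1ccc2occ(CSC(=S)N(C(C)C)C(C)C)c(=O)c2c1`: 4700 nM
compound 2 `Cc1ccc2c(=O)c(CSC(=S)N3CCCC3)coc2c1`: 3400 nM
compound 3 `COc1ccc2occ(CSC(=S)N3CCCC3)c(=O)c2c1`: 6000 nM

Within this assay the three values lie close together and none stands apart from the others beyond the scatter. Within the data shown here, the one single-point change that has been measured, (diisopropylamino in place of pyrrolidin-1-yl on a thiocarbonyl carbon), gives a 1.3-fold lower number from compound 3 to compound 1 (0.11 log units; within the scatter). Compound 2 and compound 3 carry different cores; the difference between the two cores is not broken down here.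

Compound 4 `Cc1ccc2c(=O)c(CSC(=S)N(C(C)C)C(C)C)coc2c1` is not yet measured. It differs from compound 2 by diisopropylamino in place of pyrrolidin-1-yl on a thiocarbonyl carbon, the same change as the measured one and at the same place. For compound 4 the expected step is a 1.3-fold lower number from compound 2 to compound 4 (0.10 log units; within the scatter), taken small because the earlier step of a 1.3-fold lower number from compound 3 to compound 1 (0.11 log units; within the scatter) was within the scatter. Compound 4 is estimated at 2700 nM, with a likely range from 1200 nM to 6000 nM.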

Compound 4, half-maximal inhibitory concentration: 6300 nM
For compound 4 the middle estimate is 2.3-fold (0.37 log units) below the measured one; the measured number lies above the stated range.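

In this assay, diisopropylamino in place of pyrrolidin-1-yl on the thiocarbonyl carbon gives a 1.9-fold higher number from compound 2 to compound 4 (0.27 log units; within the scatter) on the core of compound 2. Set beside the earlier step on the other core, the two readings do not separate: the same change on two cores in this assay, a 1.3-fold lower number (0.11 log units; within the scatter) from compound 3 to compound 1 and a 1.9-fold higher number (0.27 log units; within the scatter) from compound 2 to compound 4, 2.4-fold (0.37 log units) apart, within the scatter of two such steps. This shows no measurable dependence of the change on the core across these two pairs, but with both steps within the scatter it shows neither a real effect of the change on either core nor how it would behave on a third core.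

Open, on these data alone, is how other amines on the thiocarbonyl carbon, such as dimethylamino or morpholin-4-yl, would read in this assay. Also open, as far as these compounds go, is whether any such group would stand apart from these four compounds beyond the scatter.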